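Furan-2-yl to thiophen-2-yl on the shared core

The source may hold more compounds than are shown below. What is called first, only, known or untested is meant among the compounds shown, and "the series" means these compounds.

For the measured compounds named here, in a functional assay on 1A9 cells (Homo sapiens) for cytotoxicity (a lower number here means that less compound is needed, a higher number that more compound is needed for the effect), compound 1 `COC1=C(C)C(=O)/C(=C(O)/C=C/c2ccc(Br)cc2)C(=O)C1(C)C` gives 1.1 ug/mL and compound 3 `COC1=C(C)C(=O)/C(=C(O)/C=C/c2ccco2)C(=O)C1(C)C` gives 7.9 ug/mL, the higher of only two numbers. For compound 2 `COC1=C(C)C(=O)/C(=C(O)/C=C/c2ccccc2C)C(=O)C1(C)C` the entry reads "not determined" (no result reported). Compound 4 `COC1=C(C)C(=O)/C(=C(O)/C=C/c2cccs2)C(=O)C1(C)C` carries thiophen-2-yl in place of furan-2-yl on a double-bonded chain carbon bound to a double-bonded chain carbon. Going by the values given here, only one measured step bears on this, and only loosely: a 7.2-fold higher number from compound 1 to compound 3 (0.86 log units; beyond the scatter), modest but beyond the scatter, which replaced 4-bromophenyl rather than exchanging one five-membered aromatic ring for another. No change beyond the scatter is therefore expected in this assay. The estimated step is a 1.3-fold lower number from compound 3 to compound 4 (0.12 log units; within the scatter). The expected value for compound 4 is 6 ug/mL, with an estimated range of 2.5 ug/mL to 14 ug/mL.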

Compound 4, concentration for half-maximal effect: 4 ug/mL
For compound 4 the middle estimate is 1.5-fold (0.18 log units) above the measured one, within the range that was stated.
By their numbers in this assay, from the lowest: compound 1; then compounds 4 and 3 (each within the scatter of the next).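

In this assay thiophen-2-yl in place of furan-2-yl gives a 2.0-fold lower number from compound 3 to compound 4 (0.30 log units; within the scatter) and so does not separate these two five-membered aromatic rings at this place. The step from 4-bromophenyl to thiophen-2-yl is a 3.6-fold higher number from compound 1 to compound 4 (0.56 log units; beyond the scatter) and points the same way as the earlier step to furan-2-yl, so compound 1 keeps the lowest number of the three. Nothing at hand accounts for either step.

Going by these compounds, whether a pyridin-3-yl ring here would give a number nearer compound 1 or nearer compounds 3 and 4 remains open, as does the effect of an amine on the phenyl ring.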